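The source may report more compounds than this note shows. Statements on the series, on what has been measured and on what is new or still open speak of the compounds shown alone.

In an ADME assay on the whole organism with Oryza sativa as the target, tested at 1 uM (a higher number here means a weaker effect of the compound at the concentration tested, a lower number a stronger effect), the measured compounds stand as follows: compound 1 `Cc1ccc(NC(=O)N[C@@H](C)c2ccccc2)cc1` gives 99%; compound 2 `CCc1ccc(NC(=O)N[C@H](C)c2ccccc2)cc1` gives 47%; compound 3 `CCc1ccc(NC(=O)N[C@@H](C)c2ccccc2)cc1` gives 95%.

Compounds 2 and 3 are mirror forms of one another, and the step of a number 48 percentage points higher from compound 2 to compound 3 (beyond the scatter) rests on (the fact that compounds 2 and 3 differ only in the configuration as drawn). The difference between the cores of compound 1 and compound 2 is not broken down here. From compound 1 to compound 3 the change is methyl in place of hydrogen on a saturated chain carbon bound to an aromatic carbon. Compound 4 `CC(C)c1ccc(NC(=O)N[C@H](C)c2ccccc2)cc1`, not yet measured, arises from compound 2 by the same kind of change, (methyl in place of hydrogen on a saturated chain carbon bound to an aromatic carbon and a saturated chain carbon); around the place, the saturated chain carbon is bound to an aromatic carbon and a saturated chain carbon rather than to an aromatic carbon alone. Because the earlier step of a number 4 percentage points lower from compound 1 to compound 3 (within the scatter) lay within the scatter, a similarly small step is expected, a number 3 percentage points higher from compound 2 to compound 4 (within the scatter). Compound 4 is therefore estimated at 50%, likely between 25% and 80%.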

Compound 4, a percentage reported as activity, at one concentration (the size of the read-out at that concentration, not a potency): 79%
Compound 4: the middle estimate sits 29 percentage points below what was measured; the range from low to high includes it.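

On the core of compound 2, going from ethyl to isopropyl gives a number 32 percentage points higher from compound 2 to compound 4 (beyond the scatter), so the effect at the concentration tested is weaker. In this assay, adding this methyl therefore does not carry over as a fixed step from one core to the other: the same change on two cores in this assay, a number 4 percentage points lower (within the scatter) from compound 1 to compound 3 and a number 32 percentage points higher (beyond the scatter) from compound 2 to compound 4, 36 percentage points apart, beyond the scatter of two such steps

This does not show why the steps differ: they differ both in the carbon that takes the methyl and in the configuration as drawn, and two steps cannot separate these or give a rule for other cores.

The compounds shown leave open how the mirror form of compound 4 would read. They also leave open what a propyl chain or a methoxy group in place of the isopropyl would do.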